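Swapping an ether chain for a plain alkyl chain

The source may hold more compounds than are shown below. What is called first, only, known or untested is meant among the compounds shown, and "the series" means these compounds.

Measured compounds:
- Compound 1, `COc1cc(Cc2nc3c(N)nc(F)nc3n2CC2CCCO2)cc(OC)c1OC`: 22900 nM
- Compound 2, `COc1cc(Cc2nc3c(N)ncnc3n2CCOC(C)C)cc(OC)c1OC`: 38900 nM
- Compound 3, `CCCCn1c(Cc2cc(OC)c(OC)c(OC)c2Cl)nc2c(N)ncnc21`: 19100 nM

All three were tested in a functional assay on MCF7 cells (Homo sapiens) for antiproliferative activity; a higher number here means a weaker inhibitor, a lower number a stronger inhibitor. Compound 2 has the highest number of the three; its gap to compound 1 lies within the scatter, while its gap to compound 3 lies beyond it, so compound 3 is the only one shown to be clearly stronger than compound 2.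

Compound 4, `COc1cc(Cc2nc3c(N)ncnc3n2CCCC(C)C)cc(OC)c1OC`, has not been measured. It differs from compound 2 in one place: isobutyl in place of isopropoxy on a saturated chain carbon, two bonds along the chain from an aromatic nitrogen. Among the measured compounds shown here, with no measured step of this kind to lean on, a small step toward a lower number is expected, about the size of the gap between compound 2 and compound 3, but the uncertainty is wide.

Compound 4 is expected to give 25000 nM in this assay, within 9000 nM to 70000 nM, meaning an estimated step of a 1.6-fold lower number from compound 2 to compound 4 (0.19 log units; within the scatter).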

Compound 4, half-maximal inhibitory concentration: 69200 nM
For compound 4 the middle estimate is 2.8-fold (0.44 log units) below the measured one; low and high end bracket the measured number.
By their numbers in this assay, from the lowest: compounds 3, 1, 2 and 4 (each within the scatter of the next, the first and the last beyond it).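

In this assay, putting isobutyl in place of isopropoxy gives a 1.8-fold higher number from compound 2 to compound 4 (0.25 log units; within the scatter). On this chain, then, the swap makes no difference that can be told apart from the scatter, so this pair gives no sign that the oxygen of the isopropoxy group matters for this read-out. No evidence is available on what lies behind this result.

From the compounds shown here alone, whether an amine or a carboxylic acid at this place, or a longer chain, would move the number beyond the scatter remains open. A single pair also cannot show whether the same swap would behave alike on the core of compound 1.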